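Methoxy for Methyl on the Sulfonyl Ring

The compounds below may be only part of what the source reports. "The series", "measured", "known", "first", "only" and "open" are said of these compounds alone.

Compound 2 `COc1cc(Nc2ccnc(Nc3ccc(NS(=O)(=O)c4ccc(C)cc4)cc3)n2)cc(OC)c1OC` stands highest of the two numbers measured in an assay on isolated protein for inhibition of extracellular serine/threonine protein kinase FAM20C (Homo sapiens), read by malachite green, tested at 10 uM, in the presence of a further agent that is not named here (a lower number here means less inhibition, a higher number more inhibition at the concentration tested (going by the name of the read-out)), giving 28%. Its nearest neighbour is compound 1 `COc1ccc(Nc2ccnc(Nc3ccc(NS(=O)(=O)c4ccc(OC)cc4)cc3)n2)cc1`, which in this assay gives 25%; the two values lie within the scatter of each other, so the inhibition in this assay is level between the two compounds. Compound 3 `COc1ccc(S(=O)(=O)Nc2ccc(Nc3nccc(Nc4cc(OC)c(OC)c(OC)c4)n3)cc2)cc1` has not yet been measured. It differs from compound 2 in one place (methoxy in place of methyl on an aromatic carbon), on an aromatic carbon of a six-membered aromatic ring of carbon only, para to a large group. Among the measured compounds shown here, no step between measured compounds covers this change, and compound 1, which already carries the (4-methoxyphenyl)sulfonyl group but a different pattern on the other ring, gives 25%, a value within the scatter of compound 2. Compound 3 is therefore expected to give about 27% in this assay, between 12% and 42%. The step of a number 1 percentage points lower from compound 2 to compound 3 (within the scatter) is expected to be small, in no clear direction, and not beyond the scatter.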

Compound 3, a percentage reported as inhibition, at one concentration (the size of the read-out at that concentration, not a potency): 68%
For compound 3 the middle estimate is 41 percentage points below the measured one; measured number outside the range, above it.
By their numbers in this assay, from the lowest: compounds 1 and 2 (each within the scatter of the next); then compound 3.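

In this assay, methoxy in place of methyl on an aromatic carbon, para to a large group, brings a number 40 percentage points higher from compound 2 to compound 3 (beyond the scatter), so this position is far from indifferent to so small an exchange. The other single change, 3,4,5-trimethoxyphenyl in place of 4-methoxyphenyl on a nitrogen on an aromatic ring, brings a number 43 percentage points higher from compound 1 to compound 3 (beyond the scatter), and only compound 3 carries both this group and the (4-methoxyphenyl)sulfonyl group, a pairing whose large steps the two earlier compounds could not reveal. No measurement available here accounts for the gain.

On these data alone, it remains open whether an ethoxy group, a hydroxyl or a chlorine at this position would match methoxy. Also open, as far as these compounds go, is whether the gain from methoxy depends on the 3,4,5-trimethoxyphenyl group on the other side of the molecule.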